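Aryl variation on the saturated ring carbon

This account rests on a few compounds, and the source may have more. Where it says the series, first, only, none or still open, it means among the compounds named here.

Measured so far:
compound 1 `CC(C)=CCOc1ccc2c(c1)OC(c1cccc(F)c1)CC2=O` gives 4280 nM
compound 2 `COc1ccc(C2CC(=O)c3ccc(OCC=C(C)C)cc3O2)cc1` gives 10200 nM
compound 3 `CC(C)=CCOc1cc(O)c2c(c1)OC(c1cccc(F)c1)CC2=O` gives 7240 nM

In a functional assay (a lower number here means a stronger inhibitor, a higher number a weaker inhibitor), compound 3 has the second highest of the three numbers, though its gaps to compound 2 and to compound 1 both lie within the scatter; the step of a 1.7-fold higher number from compound 1 to compound 3 (0.23 log units; within the scatter) is itself within the scatter. Compound 4 `CC(C)=CCOc1cc(O)c2c(c1)OC(c1ccc(C)cc1C)CC2=O` keeps the hydroxy and alters the aryl group: 2,4-dimethylphenyl in place of 3-fluorophenyl on a saturated ring carbon. Among the measured compounds shown here, the one step that bears on this is a 2.4-fold higher number from compound 1 to compound 2 (0.38 log units; beyond the scatter), where a different aryl in place of 3-fluorophenyl gave a modest weakening. A comparable small weakening is therefore expected, a 1.5-fold higher number from compound 3 to compound 4 (0.18 log units; within the scatter), with no change remaining possible within the scatter. Compound 4 is estimated at 11000 nM, range 5000 nM to 25000 nM.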

Compound 4, half-maximal inhibitory concentration: 6380 nM
For compound 4 the middle estimate is 1.7-fold (0.24 log units) above the measured one, and the stated range covers the measured number.
By their numbers in this assay, from the lowest: compounds 1, 4, 3 and 2 (each within the scatter of the next, the first and the last beyond it).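

With the hydroxy kept, 2,4-dimethylphenyl in place of 3-fluorophenyl gives a 1.1-fold lower number from compound 3 to compound 4 (0.05 log units; within the scatter), so this aryl change on the saturated ring carbon produces no readable shift. The earlier aryl step, a 2.4-fold higher number from compound 1 to compound 2 (0.38 log units; beyond the scatter), lay beyond the scatter, but it involved a different aryl group without the hydroxy, so the two steps show that the effect is not common to every aryl change only for these compounds. Nothing available explains this result. Still open, from the compounds shown here alone, is whether an amine or a carboxylic acid on the aryl group, or cyclohexyl in its place, would move the number beyond the scatter.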